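This account rests on a few compounds, and the source may have more. Where it says the series, first, only, none or still open, it means among the compounds named here.

Measured so far:
compound 1 `CCOc1cc([C@@H](Nc2ccc3cnccc3c2)C(=O)NS(=O)(=O)c2ccccc2)ccc1OC(C)C` – in an assay on isolated protein for inhibition of Trypsin (Homo sapiens) (on this read-out higher numbers stand for weaker inhibition and lower numbers for stronger inhibition), compound 1 gives > 5000 nM, a limit of the assay.
compound 2 `CCOc1cc(C(Nc2ccc3c(N)nccc3c2)C(=O)NS(=O)(=O)c2cccc(C(N)=O)c2)ccc1OC(C)C` – compound 2 gives > 5000 nM, likewise a limit.
compound 3 `CCOc1cc(C(Nc2ccc3c(N)nccc3c2)C(=O)NS(=O)(=O)c2cccc(N)c2)ccc1OC(C)C` – compound 3 gives > 5000 nM, also a limit.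

Compound 2 thus stands only at a limit, not at a number, and the same holds for every value in the set (the limit of > 5000 nM in this assay, at which 3 of the 3 values shown sit). For the measured compounds named here, the one measured step that touches the same position, a step that the two limits leave unreadable from compound 2 to compound 3, is unreadable between two limits.

Compound 4 `CCOc1cc(C(Nc2ccc3c(N)nccc3c2)C(=O)NS(=O)(=O)c2cccc(S(N)(=O)=O)c2)ccc1OC(C)C` differs from compound 2 by sulfamoyl in place of carbamoyl on an aromatic carbon. Going by the values given here, no measured step gives a readable size for a change of this kind, so no step beyond the scatter can be predicted in either direction; the expectation is that compound 4 again falls at the limit. Compound 4 is estimated at 10000 nM (3000 nM to 50000 nM), which means an expected step that the limit leaves unreadable from compound 2 to compound 4.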

Compound 4, inhibition constant: > 5000 nM
Compound 4 was reported as a limit (the forecaster's own chance of this, stated with the estimate: 85%); the middle value is on the limit's open side.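

No step can be read between compound 4 and either compound 2 or compound 3, as every value is a limit: the limit of > 5000 nM in this assay, at which 4 of the 4 values shown sit.

The compounds shown leave open whether carbamoyl, amino and sulfamoyl differ at all in this assay.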